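This account rests on a few compounds, and the source may have more. Where it says the series, first, only, none or still open, it means among the compounds named here.

Compound 1 `CCCCCCCCC(=O)N1c2ccccc2CCC1C(=O)Nc1ccccc1C(F)(F)F`: 6180 nM
Compound 2 `CCCCCCCCC(=O)N1c2ccccc2CCC1C(=O)Nc1cc(C(F)(F)F)cc(C(F)(F)F)c1`: 2230 nM
Compound 3 `CCCCCCCCC(=O)N1c2ccccc2CCC1C(=O)Nc1ccccc1O`: 31100 nM

All three were measured in a functional assay on NUGC-3 cells (Homo sapiens) for cytotoxicity, read by sulforhodamine B assay, with a stated time of 72 h; a higher number here means a weaker inhibitor of growth, a lower number a stronger inhibitor of growth. Compound 1 holds the second highest of the three numbers; compound 2 gives a lower number, and compound 3 gives the highest. For the measured compounds named here, the only single-point step among them, a 5.0-fold higher number from compound 1 to compound 3 (0.70 log units; beyond the scatter), changes a substituent on the anilide ring and leaves the acyl chain untouched. Compound 4 `CC(=O)N1c2ccccc2CCC1C(=O)Nc1ccccc1C(F)(F)F` differs from compound 1 in hydrogen in place of heptyl on a saturated chain carbon bound to a carbonyl carbon. Going by the values given here, no measured step alters this chain, so there is no direct precedent for the change. A step of a 2.9-fold higher number from compound 1 to compound 4 (0.46 log units; beyond the scatter) towards a weaker inhibitor of growth is expected, with a wide range. The estimate for compound 4 in this assay is 18000 nM, between 5000 nM and 60000 nM.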

Compound 4, concentration for 50% growth inhibition: > 80000 nM
Compound 4 was reported as a limit; the forecaster's own chance of this, stated with the estimate: 15%; middle value at least 4.4-fold (0.64 log units) away from the limit.
By their numbers in this assay, from the lowest: compound 2; then compound 1; then compound 3. At a limit, above all of these: compound 4.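

For the compounds shown here, the acyl chain, unchanged among the earlier compounds, now proves to weigh heavily on growth inhibition in this assay: hydrogen in place of heptyl on this saturated chain carbon bound to a carbonyl carbon gives an at least 12-fold higher number from compound 1 to compound 4 (1.11 log units; beyond the scatter). Compound 4 gives > 80000 nM, which is a limit of the assay and not a number. This step on the chain is larger than the one seen on the anilide ring, a 5.0-fold higher number from compound 1 to compound 3 (0.70 log units; beyond the scatter).

The compounds shown leave open how growth inhibition responds to a butyl chain, to a longer chain such as dodecyl, or to a chain carrying an amine.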